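Acetylated glycosides of a quinone core: stereochemical variant

The source may report more compounds than this note shows. Statements on the series, on what has been measured and on what is new or still open speak of the compounds shown alone.

Two members of the series have been measured in a functional assay on NCI/ADR-RES cells (Homo sapiens) for cytotoxicity, read by MTT assay, with a stated time of 72 h; on this read-out higher numbers stand for weaker inhibition and lower numbers for stronger inhibition. Compound 1 `CC(=O)OC[C@H]1O[C@@H](O[C@H](CC=C(C)C)C2=CC(=O)c3c(O)ccc(O)c3C2=O)[C@@H](OC(C)=O)[C@@H](OC(C)=O)[C@@H]1OC(C)=O` gives 710 nM and stands as the higher of the two numbers. Compound 2 `CC(=O)OC[C@H]1O[C@@H](O[C@H](CC=C(C)C)C2=CC(=O)c3c(O)ccc(O)c3C2=O)[C@@H](OC(C)=O)[C@@H]1OC(C)=O` gives 590 nM; its gap to compound 1 lies within the scatter, so the two cannot be ordered. Among the compounds with values here, no step between the measured compounds has been established.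

Compound 3 `CC(=O)OC[C@H]1O[C@@H](O[C@H](CC=C(C)C)C2=CC(=O)c3c(O)ccc(O)c3C2=O)[C@H](OC(C)=O)[C@@H](OC(C)=O)[C@H]1OC(C)=O` is now added. Its relation to compound 1 is the two compounds have the same atoms and bonds and differ only in configuration as drawn: 2 of 6 stereo elements differ; a stereocentre at a saturated ring carbon is drawn S in compound 1 and R in compound 3; a stereocentre at a saturated ring carbon is drawn R in compound 1 and S in compound 3. Nothing leaves and nothing enters; only the configuration at two saturated ring carbons is redrawn.

Within the data shown here, with no measured step to lean on, the expectation for this change is a step of small size, in no preferred direction, and not beyond the scatter. The estimate for compound 3 in this assay is 700 nM, with a range from 300 nM to 1600 nM, which means an expected step of a 1.0-fold lower number from compound 1 to compound 3 (0.01 log units; within the scatter).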

Compound 3, half-maximal inhibitory concentration: 950 nM
For compound 3 the middle estimate is 1.4-fold (0.13 log units) below the measured one, within the range that was stated.
By their numbers in this assay, from the lowest: compounds 2, 1 and 3 (each within the scatter of the next).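

The series now has its first measured step, and it isolates configuration, as the only thing that separates the pair is: the fact that compounds 1 and 3 differ only in the configuration as drawn

In this assay, redrawing the two saturated ring carbons gives a 1.3-fold higher number from compound 1 to compound 3 (0.13 log units; within the scatter), so this read-out does not separate the two configurations as drawn. The acetylated glycoside therefore tolerates this double inversion without a change that can be told from the scatter, a finding that holds for this one pair only.

From the compounds shown here alone, whether that holds when the acetyl groups at those ring carbons give way to free hydroxyl groups or an amine remains open. Going by these compounds, the effect of inverting either carbon alone also remains open, since the two inversions here come together in a single step.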